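Swapping a Benzyl Phenyl for an Ester Group

The compounds below may be only part of what the source reports. "The series", "measured", "known", "first", "only" and "open" are said of these compounds alone.

In a functional assay on Ehrlich cells (Mus musculus) for cytotoxicity, read by MTT assay, with a stated time of 24 h (on this read-out lower numbers stand for stronger inhibition and higher numbers for weaker inhibition), compound 1 `COc1cc(C)cc2c1C(=O)C=C(c1c(C)cc3c(c1OC)C(=O)C(Nc1ccc(Cl)cc1)=CC3=O)C2=O` gives 250 nM and compound 2 `COc1cc(C)cc2c1C(=O)C=C(c1c(C)cc3c(c1OC)C(=O)C(Nc1ccc4ccccc4c1)=CC3=O)C2=O` gives 240 nM on the same core, and a 1.0-fold lower number from compound 1 to compound 2 (0.02 log units; within the scatter) counts as no real difference. Compound 3 `COc1cc(C)cc2c1C(=O)C=C(c1c(C)cc3c(c1OC)C(=O)C(NCc1ccccc1)=CC3=O)C2=O` carries a benzyl on the amine nitrogen and gives 1410 nM as the highest of the three numbers, which makes it the weakest so far. Compound 4 `CCOC(=O)CNC1=CC(=O)c2cc(C)c(C3=CC(=O)c4c(OC)cc(C)cc4C3=O)c(OC)c2C1=O` has ethoxycarbonyl in place of phenyl on a saturated chain carbon bound to an amine nitrogen. For the measured compounds named here, the full change is ethoxycarbonyl in place of phenyl on a saturated chain carbon bound to an amine nitrogen and no measured step makes this swap. Going by the values given here, the nearest evidence is a 5.6-fold higher number from compound 1 to compound 3 (0.75 log units; beyond the scatter) and also a 5.9-fold higher number from compound 2 to compound 3 (0.77 log units; beyond the scatter) and both show only that another group on an amine nitrogen can move the number modestly, without setting a direction for this swap. Little change is therefore expected in this assay with an estimated 1.1-fold higher number from compound 3 to compound 4 (0.03 log units; within the scatter) that stays within the scatter, though a modest move either way remains possible. Compound 4 is estimated at 1500 nM with 500 nM to 4500 nM as the expected range.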

Compound 4, half-maximal inhibitory concentration: 90 nM
Compound 4: middle estimate off by 17-fold (1.22 log units), on the high side, outside the stated range (below it).
By their numbers in this assay, from the lowest: compound 4; then compounds 2 and 1 (each within the scatter of the next); then compound 3.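

Ethoxycarbonyl in place of phenyl on a saturated chain carbon bound to an amine nitrogen is far from neutral in this assay: it gives a 16-fold lower number from compound 3 to compound 4 (1.19 log units; beyond the scatter), so the end group of this chain can shift the number strongly, and an aromatic ring is not required there. The result also places the ester-bearing chain ahead of the aromatic groups attached directly to the nitrogen, with a 2.7-fold lower number from compound 2 to compound 4 (0.43 log units; beyond the scatter) and a 2.8-fold lower number from compound 1 to compound 4 (0.44 log units; beyond the scatter), making compound 4 the strongest of the four. No measurement available here explains this gain.

As far as these compounds go, it remains open whether the ester itself matters or whether removing the phenyl is enough. A carboxylic acid, an amide or a longer chain ending in the same ester at this position would help separate those possibilities.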